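Capping a Phenol in a Dopamine Beta-Hydroxylase Series

This account rests on a few compounds, and the source may have more. Where it says the series, first, only, none or still open, it means among the compounds named here.

Of the compounds shown here, two sharing one core have been measured in an assay on isolated protein for inhibition of Dopamine beta-hydroxylase (Rattus norvegicus); a higher number here means a weaker inhibitor, a lower number a stronger inhibitor. Compound 1 `COc1ccc(Cn2cc[nH]c2=S)cc1OC` gives 339000 nM in this assay. Compound 2 `Oc1ccc(Cn2cc[nH]c2=S)cc1Br` gives 12000 nM in this assay, the lowest of the two numbers, and its gap to compound 1 lies beyond the usual scatter. Compound 3 `COc1ccc(Cn2cc[nH]c2=S)cc1Br` differs from compound 2 by methyl in place of hydrogen on an oxygen on an aromatic ring. Going by the values given here, no measured step matches this change, yet a weakening is expected because compound 1 gives 339000 nM with a methoxy group rather than a hydroxy group. The expected step is a 6.7-fold higher number from compound 2 to compound 3 (0.82 log units; beyond the scatter). Compound 3 is estimated at 80000 nM, within 20000 nM to 320000 nM.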

Compound 3, half-maximal inhibitory concentration: 83200 nM
Beside the measured number, compound 3's estimate is 1.0-fold (0.02 log units) below it; the range from low to high includes it.
By their numbers in this assay, from the lowest: compound 2; then compound 3; then compound 1.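

Methyl in place of hydrogen on the oxygen on the aromatic ring brings a 6.9-fold higher number from compound 2 to compound 3 (0.84 log units; beyond the scatter), the first reading of this change on its own. Bromo in place of methoxy on an aromatic carbon brings a 4.1-fold lower number from compound 1 to compound 3 (0.61 log units; beyond the scatter), so each of these two places affects the result by itself in this assay. No supporting data explain why either change acts as it does.

Still open, from the compounds shown here alone, is how an ethoxy group or an amine would compare with hydroxy at this position. Going by these compounds, whether chloro would match bromo also remains unknown.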